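Dropping the methoxy: from compound 2 to compound 3

The source may report more compounds than this note shows. Statements on the series, on what has been measured and on what is new or still open speak of the compounds shown alone.

Compound 1 `O=C(O)Cc1sc(C(c2ccccc2)c2ccc(Cl)cc2)nc1-c1ccc(Cl)cc1` and compound 2 `COc1ccc(C(c2ccccn2)c2nc(-c3ccc(Cl)cc3)c(CC(=O)O)s2)cc1` were examined in an in vitro functional assay on HEK285-7 cells for antagonist activity at prostaglandin D2 receptor 2 (Homo sapiens), read by BRET and beta-arrestin recruitment (a lower number here means a smaller maximal response, a higher number a larger maximal response), where compound 1 gives 80% and compound 2 gives 80%. On these numbers compound 2 stands level with compound 1, its nearest neighbour, with no change at the digits shown. Compound 3 `O=C(O)Cc1sc(C(c2ccccc2)c2ccccn2)nc1-c1ccc(Cl)cc1` has not yet been measured and differs from compound 2 in one place: hydrogen in place of methoxy on an aromatic carbon. Among the compounds with values here, no step between measured compounds is available, so the size of any shift in this assay is unknown, and no change beyond the scatter is expected in either direction. Compound 3 is expected to give 80% in this assay, with a range from 65% to 95%, which means an expected step of no change at the digits printed from compound 2 to compound 3 (within the scatter).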

Compound 3, largest response reached (reported as efficacy), in percent of the reference or control that the assay uses: 55%
For compound 3 the middle estimate is 25 percentage points above the measured one; the whole stated range lies above it.
By their numbers in this assay, from the lowest: compound 3; then compounds 1 and 2 (each within the scatter of the next).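

In this assay, the methoxy position proves not to be silent: hydrogen in place of methoxy on this aromatic carbon, para to a large group, gives a number 25 percentage points lower from compound 2 to compound 3 (beyond the scatter). The second single change, pyridin-2-yl in place of 4-chlorophenyl on the saturated chain carbon, gives a number 25 percentage points lower from compound 1 to compound 3 (beyond the scatter), so each of these two places registers in the maximal response. No measurement available here accounts for either step. Open, as far as these compounds go, is whether a hydroxyl or a methyl on that same aromatic carbon would match methoxy or hydrogen.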